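A few compounds are considered here, and "the series" means these few. Any claim that something is new, unique, unknown or untested is made for them only; others in the source may bear on it.

Measured so far in a functional assay on BXPC-3 cells (Homo sapiens) for inhibition, read by MTT assay, with a stated time of 7 days; on this read-out higher numbers stand for weaker inhibition and lower numbers for stronger inhibition:
Compound 1 `CCN(CC)S(=O)(=O)c1ccc(S(=O)(=O)N2CCC[C@@H](C(=O)N3CCC(F)(F)CC3)C2)cc1` gives 120 nM.
Compound 2 `CCN(CC)S(=O)(=O)c1ccc(S(=O)(=O)N2CCC[C@@H](C(=O)N3CCS(=O)(=O)CC3)C2)cc1` gives 4430 nM.
Compound 3 `CCN(CC)S(=O)(=O)c1ccc(S(=O)(=O)N2CCC[C@@H](C(=O)N3CCC(O)CC3)C2)cc1` gives 4710 nM.

Compound 3 carries the highest number of the three in this assay. Its nearest neighbour is compound 2, and the gap a 1.1-fold higher number from compound 2 to compound 3 (0.03 log units; within the scatter) lies within the scatter, so no order between compounds 2 and 3 can be read. Compound 1 stands far apart: a 39-fold higher number from compound 1 to compound 3 (1.59 log units; beyond the scatter), a large step, beyond the scatter.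

Compound 4 `CCN(CC)S(=O)(=O)c1ccc(S(=O)(=O)N2CCC[C@@H](C(=O)NC3COC3)C2)cc1` is not yet measured. Its difference from compound 3: (oxetan-3-yl)amino in place of 4-hydroxypiperidin-1-yl on a carbonyl carbon.

Within the data shown here, no measured step exchanges one ring-bearing amide substituent for another of a different ring size while keeping the amide otherwise intact. Among the measured compounds shown here, the one step between two substituents that are both not 4,4-difluoropiperidin-1-yl, a 1.1-fold higher number from compound 2 to compound 3 (0.03 log units; within the scatter), stayed within the scatter. The two large steps, a 37-fold higher number from compound 1 to compound 2 (1.57 log units; beyond the scatter) and a 39-fold higher number from compound 1 to compound 3 (1.59 log units; beyond the scatter), each leave the 4,4-difluoropiperidin-1-yl group behind, and compound 4 also lacks that group, so they give no reason for a move back toward compound 1. The step from compound 3 is therefore expected to lie within the scatter, estimated as a 1.1-fold higher number from compound 3 to compound 4 (0.03 log units; within the scatter). For compound 4 the expected value in this assay is 5000 nM, within the range 1500 nM to 16000 nM.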

Compound 4, half-maximal inhibitory concentration: 13800 nM
Compound 4: the middle estimate sits 2.8-fold (0.44 log units) below what was measured, and the stated range covers the measured number.
By their numbers in this assay, from the lowest: compound 1; then compounds 2 and 3 (each within the scatter of the next); then compound 4.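

In this assay, the position on the carbonyl carbon now shows a spread among groups lacking the 4,4-difluoropiperidin-1-yl group, which compounds 2 and 3 did not show: a 2.9-fold higher number from compound 3 to compound 4 (0.47 log units; beyond the scatter) and a 3.1-fold higher number from compound 2 to compound 4 (0.49 log units; beyond the scatter), both modest but beyond the scatter. Among these compounds, with a 120-fold higher number from compound 1 to compound 4 (2.06 log units; beyond the scatter), the largest step so far, compound 4 is the weakest of the four, and (oxetan-3-yl)amino, with its four-membered ring, gives the highest number yet seen at this position. No measured information on hand accounts for these steps.

The change from compound 3 to compound 4 alters ring size, the ring's hetero atom placement and the presence of the amide hydrogen in one move, so the compounds shown leave open which of these goes with the higher number. Also open, on these data alone, is how a (methyl)(oxetan-3-yl)amino group, which lacks the amide hydrogen, would compare with compound 4, and whether a plain piperidin-1-yl or a 3,3-difluoroazetidin-1-yl group would stay near compound 1 or move toward the others.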